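This account rests on a few compounds, and the source may have more. Where it says the series, first, only, none or still open, it means among the compounds named here.

Compound 1 `Cc1c(C(=O)Nc2c(F)cc(-c3cccc(F)c3)cc2F)nc2ccc(F)cc2c1O` and compound 2 `Cc1c(C(=O)Nc2c(F)cc(-c3cccc(F)c3)cc2F)nc2ccc(F)cc2c1C(=O)O` share one core and differ at a single aromatic carbon. In a functional assay on Hep 3B2 cells (Homo sapiens) for antiproliferative activity, read by MTT assay, with a stated time of 24 h, tested at 3.7 ug/mL (on this read-out higher numbers stand for a stronger effect at the one concentration tested and lower numbers for a weaker effect), compound 1 gives 22.3%, while compound 2 gives 11.2%; the step is a number 11.1 percentage points lower from compound 1 to compound 2 (beyond the scatter). Going by the values given here, compound 2 thus stands lowest of the two numbers so far, with compound 1 as its only neighbour, beyond the scatter above it.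

Compound 3 `Cc1c(C(=O)Nc2c(F)cc(-c3cccc(F)c3)cc2F)nc2ccc(C(F)(F)F)cc2c1C(=O)O` is the next member of the series, reached from compound 2 by a single change: trifluoromethyl in place of fluoro on an aromatic carbon. Among the compounds with values here, no measured step bears on this change; the one step seen, a number 11.1 percentage points lower from compound 1 to compound 2 (beyond the scatter), concerns a different group at a different carbon and gives no guide here. With nothing comparable measured, the expectation in this assay is a step of no more than the scatter, in either direction. Compound 3 is therefore expected to give about 12%, with a range from 0% to 28%. That estimate corresponds to an expected step of a number 0.8 percentage points higher from compound 2 to compound 3 (within the scatter).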

Compound 3, a percentage reported as inhibition, at one concentration (the size of the read-out at that concentration, not a potency): 21.3%
Compound 3: middle estimate off by 9.3 percentage points, on the low side; measured number inside the range.
By their numbers in this assay, from the lowest: compound 2; then compounds 3 and 1 (each within the scatter of the next).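

In this assay, trifluoromethyl in place of fluoro gives a number 10.1 percentage points higher from compound 2 to compound 3 (beyond the scatter). Going by these compounds alone, this is the first measured change at this aromatic carbon, meta to a fused ring and para to a fused ring, and it shows that, with the carboxy group held in place, the group at this carbon can move the read-out beyond the scatter. No measurement available here accounts for the step.

From the compounds shown here alone, what a chloro, methoxy or amino group would give at this carbon remains open. Also open, going by these compounds, is whether trifluoromethyl in place of fluoro gives a similar step with hydroxy rather than carboxy on the shared core, and whether the difference at this one concentration carries over to potency.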